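Replacing 1,3-Thiazol-2-yl with 3-Hydroxyphenyl in Compound 1

This account rests on a few compounds, and the source may have more. Where it says the series, first, only, none or still open, it means among the compounds named here.

Of the compounds shown here, two have so far been measured in a functional assay on HEK293 cells for agonist activity at D(4) dopamine receptor (Homo sapiens), read by FLIPR; on this read-out higher numbers stand for larger maximal responses and lower numbers for smaller maximal responses. Compound 1 `Cc1cccc(NC(=O)CN2CCC(c3nccs3)CC2)c1` gives 62% in this assay. Compound 2 `Cc1cccc(C(=O)NCN2CCC(c3ccccn3)CC2)c1` gives 67% in this assay. Compound 1 has the lower of the two numbers, but its gap to compound 2 lies within the scatter of repeated measurements, so the two cannot be told apart.

Compound 3 `Cc1cccc(NC(=O)CN2CCC(c3cccc(O)c3)CC2)c1` has not yet been measured. It differs from compound 1 in one place: 3-hydroxyphenyl in place of 1,3-thiazol-2-yl on a saturated ring carbon. Within the data shown here, no measured pair of compounds shows what a change of this kind does, so there is nothing to rest a direction on beyond the two numbers at hand. The expected step of a number 2 percentage points lower from compound 1 to compound 3 (within the scatter) is therefore small, in either direction, or none beyond the scatter. Compound 3 is expected to give about 60%, with a likely range from 40% to 85%.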

Compound 3, largest response reached (reported as efficacy), in percent of the reference or control that the assay uses: 66%
Estimate against measurement, compound 3: 6 percentage points below; measured number inside the range.
By their numbers in this assay, from the lowest: compounds 1, 3 and 2 (each within the scatter of the next).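

Replacing 1,3-thiazol-2-yl with 3-hydroxyphenyl on this saturated ring carbon gives a number 4 percentage points higher from compound 1 to compound 3 (within the scatter) in this assay on the core of compound 1. This is the first step shown at this position, and it places a five-membered aromatic ring with 2 hetero atoms and a six-membered aromatic ring of carbon only, carrying a hydroxyl group, within the scatter of each other on this read-out of maximal response. Nothing shown here gives a reason for this result.

As far as these compounds go, whether the hydroxyl group itself counts for anything remains open, since the values for a plain phenyl or a 3-methoxyphenyl at this position are unknown here. Also open, from the compounds shown here alone, is what an aminophenyl or a saturated ring such as cyclohexyl would give in this place.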